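Swapping pyridine for dichlorophenyl on the sulfonyl sulfur

The source may report more compounds than this note shows. Statements on the series, on what has been measured and on what is new or still open speak of the compounds shown alone.

Three compounds share one core and differ only in the group on the sulfonyl sulfur. Compound 1 `Cc1ccc(S(=O)(=O)N2CCC(N3CCC(C)CC3)CC2)cc1C` carries 3,4-dimethylphenyl; in an ADME assay on HCT-116 cells (Homo sapiens) for cytotoxicity, read by CellTiter-Glo, with a stated time of 72 h (on this read-out higher numbers stand for weaker inhibition and lower numbers for stronger inhibition), compound 1 gives only the limit > 5000 nM, not a number. Compound 2 `CC1CCN(C2CCN(S(=O)(=O)c3ccc(Cl)c(Cl)c3)CC2)CC1` carries 3,4-dichlorophenyl, and in this assay compound 2 likewise reaches only the limit > 5000 nM. Compound 3 `CC1CCN(C2CCN(S(=O)(=O)c3cccnc3)CC2)CC1` carries pyridin-3-yl; in this assay compound 3 shows only the limit > 10000 nM. Compound 3 thus stands at one limit among three limits, and the steps a step that the two limits leave unreadable from compound 1 to compound 2, a step that the two limits leave unreadable from compound 1 to compound 3 and a step that the two limits leave unreadable from compound 2 to compound 3 cannot be sized. Compound 4 `CC1CCN(C2CCN(S(=O)(=O)c3cc(Cl)cc(Cl)c3)CC2)CC1` differs from compound 3 by 3,5-dichlorophenyl in place of pyridin-3-yl on a sulfonyl sulfur. Among the measured compounds shown here, no measured step covers this change; compound 2 with its 3,4-dichlorophenyl also sits at a limit (the limit of > 5000 nM in this assay, at which 2 of the 3 values shown sit), which suggests no readable step. Compound 4 is expected to stay near the limits, the expected step being an at least 1.1-fold lower number from compound 3 to compound 4 (0.04 log units; that floor lies within the scatter). The estimate for compound 4 is 9000 nM, with a range from 3000 nM to 30000 nM.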

Compound 4, half-maximal inhibitory concentration: > 5000 nM
Compound 4: only a limit was reported (the forecaster's own chance of this, stated with the estimate: 80%); the middle value does not contradict the limit.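

In this assay, among the compounds shown here, compound 4 gives only a limit, like compound 1, compound 2 and compound 3, so no step between them can be read. From the compounds shown here alone, whether any of these four compounds has a measurable potency stays open.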